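The source may report more compounds than this note shows. Statements on the series, on what has been measured and on what is new or still open speak of the compounds shown alone.

Cytotoxicity notes on the series in an ADME assay on THP-1 cells (Homo sapiens) for cytotoxicity, read by resazurin assay, with a stated time of 48 h; on this read-out higher numbers stand for weaker inhibition and lower numbers for stronger inhibition. Compound 1 `O=c1c(O)cccn1Cc1ccc(-c2ccccc2)cc1` gives > 10 ug/mL in this assay, which is a limit of the assay and not a number. Compound 2 `CN(C)c1ccc(-c2ccc(Cn3cccc(O)c3=O)cc2)cc1`, which carries dimethylamino in place of hydrogen on an aromatic carbon, is likewise reported in this assay only as the limit > 10 ug/mL. The step that the two limits leave unreadable from compound 1 to compound 2 is therefore not readable. Compound 3 `Oc1cccn(Cc2cn(-c3ccccc3)nn2)c1=S` also gives in this assay only the limit > 10 ug/mL. The difference between the core of compound 1 and the core of compound 3 is not broken down here. Compound 4 `CN(C)c1ccc(-n2cc(Cn3cccc(O)c3=S)nn2)cc1` is not yet measured; relative to compound 3 it carries the same change, namely (dimethylamino in place of hydrogen on an aromatic carbon). In this assay the step that the limit leaves unreadable from compound 3 to compound 4 is expected to stay small, resting on (the limit of > 10 ug/mL in this assay, at which 3 of the 3 values shown sit), where every measured value of the series sits. Compound 4 is expected to come out at 20 ug/mL, most likely reported once more as a limit.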

Compound 4, half-maximal inhibitory concentration: > 10 ug/mL
Compound 4: only a limit was reported; the forecaster's own chance of this, stated with the estimate: 85%; the middle value lies beyond the limit too.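

No new step can be read: compound 3 and compound 4 are both reported only as limits in this assay. The compounds shown leave open how far any of them lies beyond that limit, and so what dimethylamino in place of hydrogen changes, because every value sits at one limit: the limit of > 10 ug/mL in this assay, at which 4 of the 4 values shown sit.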